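Swapping a Naphthyl Amide for a Short Chain Amide

The source may report more compounds than this note shows. Statements on the series, on what has been measured and on what is new or still open speak of the compounds shown alone.

Measured compounds:
compound 1: `O=C(CSc1ccc(Cl)cc1)Nc1ccc2nc(NC(=O)c3ccc4ccccc4c3)sc2c1` — 4040 nM
compound 2: `O=C(CSc1ccc2ccccc2c1)Nc1ccc2nc(NC(=O)c3ccc(C(F)(F)F)cc3)sc2c1` — 300 nM

Of the compounds shown here, two built on the same core have been tested. In a functional assay on HCT-116 cells (Homo sapiens) for antiproliferative activity, read by MTT assay, with a stated time of 72 h (on this read-out lower numbers stand for stronger inhibition and higher numbers for weaker inhibition), compound 1 gives 4040 nM, the higher of the two numbers. Compound 2 gives 300 nM, and the gap between the two lies well beyond the scatter of this assay, though compound 2 differs from compound 1 in more than one place, so no single change can be read from that gap.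

Compound 3 `CCCC(=O)Nc1nc2ccc(NC(=O)CSc3ccc(Cl)cc3)cc2s1` differs from compound 1 in exactly one place: propyl in place of naphthalen-2-yl on a carbonyl carbon. For the measured compounds named here, no measured pair isolates this change, so any expectation rests on the single starting number of compound 1. Compound 3 is expected to show a modest step toward a higher number, a 1.7-fold higher number from compound 1 to compound 3 (0.24 log units; within the scatter), close to the edge of the scatter. Compound 3 is accordingly estimated at 7000 nM, with a range from 2000 nM to 25000 nM.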

Compound 3, half-maximal inhibitory concentration: 2120 nM
The estimate for compound 3 lay 3.3-fold (0.52 log units) above the measured number; measured number inside the range.
By their numbers in this assay, from the lowest: compound 2; then compounds 3 and 1 (each within the scatter of the next).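

In this assay, putting propyl in place of naphthalen-2-yl on the carbonyl carbon gives a 1.9-fold lower number from compound 1 to compound 3 (0.28 log units; within the scatter). For the compounds shown here, this is the first single-place reading at this position, and it shows that removing both six-membered aromatic rings, with the group going from 10 heavy atoms to 3, leaves no difference that can be told from the scatter. For this pair, then, the naphthalen-2-yl group is not required for a number in this range, though no measurement shown explains why the two compounds read alike.

Still open, going by these compounds, is whether an amine, a carboxylic acid or a longer chain on this carbonyl carbon would move the number beyond the scatter. On these data alone, it is also open whether propyl would behave the same way alongside the other groups of compound 2, which gives 300 nM.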